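Spirocyclic amide replacing acetyl on the amine nitrogen

This account rests on a few compounds, and the source may have more. Where it says the series, first, only, none or still open, it means among the compounds named here.

Compound 1 `CC(C)CN1CCc2nc(C#Cc3ccccc3)sc2C1`: in an assay on HEK293 cells for positive allosteric modulation of metabotropic glutamate receptor 5 (Homo sapiens), read by FLIPR, with a stated time of 1 h (a higher number here means that more compound is needed for the effect, a lower number that less compound is needed), compound 1 gives > 10000 nM, which is a limit of the assay and not a number.
Compound 2 `CC(=O)N1CCc2nc(C#Cc3ccccc3)sc2C1`: in this assay compound 2 gives > 10000 nM, likewise a limit of the assay.

Within the data shown here, compound 2 therefore stands only at a limit; the one other value shown is also a limit (the limit of > 10000 nM in this assay, at which 2 of the 2 values shown sit). The step that the two limits leave unreadable from compound 1 to compound 2 is consequently unreadable and gives no sense of how changes on the amine nitrogen move the half-maximal effective concentration. Compound 3 `O=C(C1CC12CCC2)N1CCc2nc(C#Cc3ccccc3)sc2C1` is the next compound: a group of 6 heavy atoms (6 carbon; one three-membered non-aromatic ring of carbon only, one four-membered non-aromatic ring of carbon only) in place of one carbon atom, on a carbonyl carbon. Among the measured compounds shown here, no measured step bears on this change with a readable size, so no direction can be taken from the data. Compound 3 is therefore expected to sit near the same limit, with an estimated 15000 nM (range 3000 nM to 60000 nM), and the step that the limit leaves unreadable from compound 2 to compound 3 is an expectation only, not a reading from any measured step.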

Compound 3, half-maximal effective concentration: 3.9 nM
For compound 3 the middle estimate is 3800-fold (3.59 log units) above the measured one, outside the stated range (below it).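

In this assay, among these compounds, the group on the carbonyl carbon proves able to carry a readable response on the shared core, which the earlier compounds could not show: the limit of > 10000 nM in this assay, at which 2 of the 3 values shown sit.
Swapping methyl for the spirocyclic group gives an at least 2500-fold lower number from compound 2 to compound 3 (3.40 log units; beyond the scatter) on that carbonyl carbon, so this single change separates a compound at the limit from one with a measured value. Set against the isobutyl group on the amine nitrogen, the spirocyclic amide gives an at least 2500-fold lower number from compound 1 to compound 3 (3.40 log units; beyond the scatter) in the same assay.

The compounds shown leave open whether both carbon rings are needed, or whether a cyclopropyl group, a cyclobutyl group or a tert-butyl group on the carbonyl carbon would do as well. They also leave open whether the carbonyl itself matters, as a plain amine carrying the same spirocyclic group would show.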